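Isopropyl in Place of Trichloroethyl: An Expectation

The source may hold more compounds than are shown below. What is called first, only, known or untested is meant among the compounds shown, and "the series" means these compounds.

compound 1 `C[C@@H]1CN(C(=O)c2nc(Nc3cc(C4CC4)[nH]n3)c3cc(Cl)ccc3n2)CCN1C(=O)OC(C)(C)C`: 0.1%
compound 2 `C[C@@H]1CN(C(=O)c2nc(Nc3cc(C4CC4)[nH]n3)c3cc(Cl)ccc3n2)CCN1C(=O)OCC(Cl)(Cl)Cl`: -1.5%

In an assay for inhibition of serine/threonine-protein kinase PAK 4 (Homo sapiens), read by FRET and Z'-LYTE, with a stated time of 60 min, tested at 0.5 uM, in the presence of a further agent that is not named here (a lower number here means a weaker effect, a higher number a stronger effect of the compound at the concentration tested), compound 1 gives 0.1% and compound 2 gives -1.5%. Compound 2 cannot be set apart from compound 1 on these numbers, since the step of a number 1.6 percentage points lower from compound 1 to compound 2 (within the scatter) lies within the scatter. Compound 3 `CC(C)OC(=O)N1CCN(C(=O)c2nc(Nc3cc(C4CC4)[nH]n3)c3cc(Cl)ccc3n2)C[C@H]1C` differs from compound 2 at the same oxygen: isopropyl in place of 2,2,2-trichloroethyl on an oxygen next to a carbonyl group. Among the measured compounds shown here, the only measured step that bears on this place, a number 1.6 percentage points lower from compound 1 to compound 2 (within the scatter), was within the scatter, so no step beyond the scatter is expected in this assay from compound 2 to compound 3. Compound 3 is therefore expected to give 0%, within -8% to 8%, an expected step of a number 1.5 percentage points higher from compound 2 to compound 3 (within the scatter).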

Compound 3, a percentage reported as inhibition, at one concentration (the size of the read-out at that concentration, not a potency): 26.9%
Compound 3: the middle estimate sits 26.9 percentage points below what was measured; the whole stated range lies below it.
By their numbers in this assay, from the lowest: compounds 2 and 1 (each within the scatter of the next); then compound 3.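

In this assay, the group on this oxygen proves able to move the read-out: isopropyl in place of 2,2,2-trichloroethyl brings a number 28.4 percentage points higher from compound 2 to compound 3 (beyond the scatter), and hydrogen in place of one methyl of tert-butyl brings a number 26.8 percentage points higher from compound 1 to compound 3 (beyond the scatter). Compound 1 and compound 2 alone could not show this, as their numbers lie within the scatter of each other. Nothing measured here accounts for the change. Going by these compounds, whether ethyl, methyl or cyclobutyl on the same oxygen would give a higher or lower number stays open, and the number for compound 3 tells only of the size of its effect at the one concentration tested.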